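The source may report more compounds than this note shows. Statements on the series, on what has been measured and on what is new or still open speak of the compounds shown alone.

Going by the values given here, compound 3, with the structure `O=C(O)[C@H]1NC[C@H](O)[C@H](O)[C@H]1O`, stands highest of the three compounds measured so far in an assay for inhibition of alpha-N-acetylgalactosaminidase (Gallus gallus), tested at 1000 uM (on this read-out lower numbers stand for less inhibition and higher numbers for more inhibition at the one concentration tested (going by the name of the read-out)), where compound 3 gives 21%. Compound 1, with the structure `O=C(O)[C@H]1NC[C@@H](O)[C@H](O)[C@H]1O`, gives 4.2%, and compound 2, with the structure `O=C(O)[C@H]1NC[C@H](O)[C@H](O)[C@@H]1O`, gives 4.5%. The step of a number 16.8 percentage points higher from compound 1 to compound 3 (beyond the scatter) and the step of a number 16.5 percentage points higher from compound 2 to compound 3 (beyond the scatter) both show that altering a single stereocentre can move the number by a modest amount, whereas the step of a number 0.3 percentage points higher from compound 1 to compound 2 (within the scatter), which alters two stereocentres at once, stays within the scatter.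

Compound 4, with the structure `O=C(O)[C@H]1NC[C@H](O)[C@@H](O)[C@@H]1O`, has not yet been measured. Relative to compound 3 the change is the two compounds have the same atoms and bonds and differ only in configuration as drawn: 2 of 4 stereo elements differ; a stereocentre at a saturated ring carbon is drawn S in compound 3 and R in compound 4; a stereocentre at a saturated ring carbon is drawn S in compound 3 and R in compound 4. The measured steps thus offer two precedents for configurational change: the one-centre steps to compound 3 were modest and both ran upward toward compound 3, while the two-centre step between compound 1 and compound 2 did nothing beyond the scatter. Since compound 3 already holds the highest number, and every other configuration examined sits lower, compound 4 is expected to fall back toward the region occupied by compound 1 and compound 2, with a downward step of about a number 13 percentage points lower from compound 3 to compound 4 (beyond the scatter). The value of compound 4 is estimated at 8%, within a range from 2% to 25%.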

Compound 4, a percentage reported as inhibition, at one concentration (the size of the read-out at that concentration, not a potency): 0.2%
Estimate against measurement, compound 4: 7.8 percentage points above; the whole stated range lies above it.
By their numbers in this assay, from the lowest: compounds 4, 1 and 2 (each within the scatter of the next); then compound 3.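

Going by these compounds alone, the step of a number 20.8 percentage points lower from compound 3 to compound 4 (beyond the scatter) shows that a change at two stereocentres can move the number in this assay beyond the scatter, which the only earlier two-centre change did not do, and the drop can be put down to configuration alone because nothing else separates the pair: the fact that compounds 3 and 4 differ only in the configuration as drawn. The step of a number 4.3 percentage points lower from compound 2 to compound 4 (within the scatter) involves only one stereocentre, so a single-centre change does not always move the number as it did on the way to compound 3, and the step of a number 4 percentage points lower from compound 1 to compound 4 (within the scatter) involves three stereocentres with no larger result. Across these compounds, then, the count of altered centres does not set the size of a step, and only the particular configuration of compound 3 stands apart from compound 1, compound 2 and compound 4.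

On these data alone, it remains open whether the configuration of compound 3 would keep its number if the carboxylic acid gave way to a primary alcohol or an amide, or if an acetamido group were added to the shared core. A reading at one concentration also leaves the potency of compound 3 unknown.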